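A few compounds are considered here, and "the series" means these few. Any claim that something is new, unique, unknown or untested is made for them only; others in the source may bear on it.

Measured so far in an ADME assay on microsomes from liver (Canis lupus familiaris) for metabolic stability; on this read-out lower numbers stand for a shorter-lived compound and higher numbers for a longer-lived compound:
Compound 1, `Nc1nc(NCCNc2ncc(-c3ncc[nH]3)c(-c3ccc(C(F)(F)F)cc3)n2)ccc1[N+](=O)[O-]` — only a limit of this assay, > 0.5 h
Compound 2, `Nc1nc(NCCNc2ncc(-c3ncc[nH]3)c(-c3ccc(F)cc3Br)n2)ccc1[N+](=O)[O-]` — only a limit of this assay, > 0.5 h

Both results are limits, not numbers: the read-out stopped at the edge of what this assay reports. Going by the values given here, compound 2 therefore stands at that edge, and the one measured step, a step that the two limits leave unreadable from compound 1 to compound 2, cannot be sized, since it runs from one limit to another. Among the compounds with values here, the only evidence on the numbers is the limit of > 0.5 h in this assay, at which 2 of the 2 values shown sit.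

Compound 3, `COc1cc(Cl)ccc1-c1nc(NCCNc2ccc([N+](=O)[O-])c(N)n2)ncc1-c1ncc[nH]1`, is not yet measured. It differs from compound 2 in one place:

4-chloro-2-methoxyphenyl in place of 2-bromo-4-fluorophenyl on an aromatic carbon

The measured step from compound 1 to compound 2 touches the same position of the shared core, so it is the one that bears on this change, but its size is not readable. No direction can be drawn from it. The expectation for compound 3 rests only on the fact that both measured compounds sit at the limit, so the step that the limit leaves unreadable from compound 2 to compound 3 is estimated to stay within the scatter. Compound 3 is expected to give about 1.5 h in this assay, within a range from 0.5 h to 5 h, most likely again reported only as a limit.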

Compound 3, half-life: > 0.5 h
Compound 3 gave a limit, no number (the forecaster's own chance of this, stated with the estimate: 75%); the middle value is on the limit's open side.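

No new step can be read between compound 3 and either compound 1 or compound 2, because all three results are limits rather than numbers: the limit of > 0.5 h in this assay, at which 3 of the 3 values shown sit.

The compounds shown leave open how long each one actually lasts in this assay, and so whether swapping the substituted phenyl group on the shared core changes the half-life at all.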